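The source may hold more compounds than are shown below. What is called first, only, known or untested is meant among the compounds shown, and "the series" means these compounds.

In a functional assay on Vero cells (Chlorocebus sabaeus) for cytotoxicity (on this read-out lower numbers stand for stronger inhibition and higher numbers for weaker inhibition), compound 1 (`OC[C@H]1[C@H](n2cnc3c(O)ncnc32)S[C@@H]1CO`), which also carries hydroxy, gives > 100000 nM, a limit of the assay and not a number. Compound 2 (`Nc1ncnc2c1ncn2[C@H]1S[C@@H](CO)[C@@H]1CO`) gives > 100000 nM, likewise only a limit. That leaves one finding so far: the limit of > 100000 nM in this assay, at which 2 of the 2 values shown sit. Compound 3 (`OC[C@H]1[C@H](CO)S[C@@H]1n1cnc2c(O)ncnc21`) differs from compound 2 by hydroxy in place of amino on an aromatic carbon, which means hydroxy in place of amino on an aromatic carbon. For the measured compounds named here, no measured step shows this change, and none beyond the scatter is expected in this assay. The estimated a number no higher from compound 2 to compound 3 (the limit leaves the size open) is expected to be small. Compound 3 is expected to give about 100000 nM, with an estimated range of 40000 nM to 200000 nM.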

Compound 3, half-maximal inhibitory concentration: > 100000 nM
Compound 3 gave a limit, no number; the forecaster's own chance of this, stated with the estimate: 90%; the middle value lies on the limit itself.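

Compound 3 also gives only a limit of the assay, so its steps from compound 2 and from compound 1 cannot be read: the limit of > 100000 nM in this assay, at which 3 of the 3 values shown sit.

Still open, as far as these compounds go, is whether swapping amino for hydroxy, or inverting the configuration, changes anything in this assay.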